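Benzylamino to cyclopentylamino on the shared core

This account rests on a few compounds, and the source may have more. Where it says the series, first, only, none or still open, it means among the compounds named here.

In a functional assay on ECa-109 cells for inhibition, with ECa-109 cell line (Homo sapiens) as the target, read by sulforhodamine B assay (on this read-out higher numbers stand for weaker inhibition and lower numbers for stronger inhibition), compound 1 `O=C1C=C(NCc2ccccc2)C(=O)c2c1nc1n2[C@H]2OC[C@@H](O)[C@H]2OC1` gives > 8000 nM as a limit and not a number. Compound 2 `CCc1ccc(NC2=CC(=O)c3c(nc4n3[C@H]3OC[C@@H](O)[C@H]3OC4)C2=O)cc1` gives > 4000 nM as a limit too. Compound 3 `COc1ccccc1NC1=CC(=O)c2c(nc3n2[C@H]2OC[C@@H](O)[C@H]2OC3)C1=O` gives > 4000 nM as a limit as well. Compound 1 therefore has no readable rank against the other two. For the measured compounds named here, the only measured step is a step that the two limits leave unreadable from compound 2 to compound 3 and it offers no size to carry forward. Compound 4 `O=C1C=C(NC2CCCC2)C(=O)c2c1nc1n2[C@H]2OC[C@@H](O)[C@H]2OC1` has cyclopentyl in place of benzyl on an amine nitrogen, with cyclopentyl in place of benzyl on an amine nitrogen as the counted difference. The sole reference point remains the limit of compound 1 at > 8000 nM for this expectation. The expected result is a step that the limit leaves unreadable from compound 1 to compound 4 with no step beyond the scatter in either direction. Compound 4 is estimated at 9000 nM with 3000 nM to 25000 nM as the expected range.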

Compound 4, half-maximal inhibitory concentration: > 16000 nM
Compound 4: only a limit was reported; the forecaster's own chance of this, stated with the estimate: 75%; middle value at least 1.7-fold (0.24 log units) from the limit.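

In this assay compound 4 gives > 16000 nM, a limit and not a number, so its step from compound 1 cannot be read. The compounds shown leave open whether benzylamino or cyclopentylamino on the shared core gives stronger inhibition.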